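Xanthine series: cyclohexylamino versus 2-methylcyclopropyl

The source may report more compounds than this note shows. Statements on the series, on what has been measured and on what is new or still open speak of the compounds shown alone.

Compound 1 `CCCn1c(=O)c2nc(C3CCCC3C(=O)O)[nH]c2n(CCC)c1=O` gives 100 nM; 140 nM (2 entries) in a functional assay for antagonist activity at adenosine receptor A1 (Homo sapiens); on this read-out higher numbers stand for weaker inhibition and lower numbers for stronger inhibition.
Compound 2 `CCCn1c(=O)c2nc(CC3CCCC3)[nH]c2n(CCC)c1=O` gives 69 nM in this assay.
Compound 3 `CCCn1c(=O)c2nc(NC3CCCCC3)[nH]c2n(CCC)c1=O` gives 14 nM in this assay.

Compound 3 holds the lowest number of the two single values; its nearest neighbour is compound 2, from which a 4.9-fold lower number from compound 2 to compound 3 (0.69 log units; beyond the scatter), the change being cyclohexylamino in place of cyclopentylmethyl. Compound 1 carries two entries the several entries of compound 1 in this assay, 100 nM; 140 nM (2 entries) and is kept as a wider reference without a single number.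

Compound 4 `CCCn1c(=O)c2nc(C3CC3C)[nH]c2n(CCC)c1=O` differs from compound 3 by 2-methylcyclopropyl in place of cyclohexylamino on an aromatic carbon. Among the measured compounds shown here, the one measured step that bears on this position is a 4.9-fold lower number from compound 2 to compound 3 (0.69 log units; beyond the scatter), where a carbocycle linked through a chain was swapped for a ring linked through an amino group and the number fell. Going back to a small carbocycle joined directly, the reverse direction is expected, and a step of roughly that size is expected: a 6.4-fold higher number from compound 3 to compound 4 (0.81 log units; beyond the scatter). For compound 4 a value of about 90 nM is estimated, within 30 nM to 300 nM.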

Compound 4, inhibition constant: 11 nM
Compound 4: the middle estimate sits 8.2-fold (0.91 log units) above what was measured; measured number below the stated range.
By their numbers in this assay, from the lowest: compounds 4 and 3 (each within the scatter of the next); then compound 2.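

In this assay the amino link is not required at this position: compound 4 carries 2-methylcyclopropyl, with 0 hydrogen-bond donors and one three-membered ring of carbon only, and the step to it from cyclohexylamino stays small (a 1.3-fold lower number from compound 3 to compound 4 (0.10 log units; within the scatter)). Set against cyclopentylmethyl, the same group gives a clear step (a 6.3-fold lower number from compound 2 to compound 4 (0.80 log units; beyond the scatter)), so both compound 3 and compound 4 stand apart from compound 2, whether the ring is joined directly or through nitrogen. Nothing at hand gives a cause for this result.

On these data alone, what the methyl on the three-membered ring contributes remains open, since a plain cyclopropyl would be needed for that comparison. Also open, as far as these compounds go, is whether a cyclopentyl ring joined directly to the aromatic carbon, or a cyclopropylamino group, would fall with compound 3 and compound 4 or with compound 2.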